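The compounds below may be only part of what the source reports. "The series", "measured", "known", "first", "only" and "open" are said of these compounds alone.

Three amides on a shared core have been tested in a functional assay on KOPN-8 cells (Homo sapiens) for antiproliferative activity, with a stated time of 72 h; a lower number here means that less compound is needed, a higher number that more compound is needed for the effect. Compound 1 `COc1cc(OC)c2c(=O)cc(C(=O)Nc3ccc(N4CCN(C)CC4)cc3)[nH]c2c1` gives only a limit, > 19800 nM. Compound 2 `COc1cc(OC)c2c(=O)cc(C(=O)Nc3ccc(Oc4ccc([N+](=O)[O-])cc4)cc3)[nH]c2c1` gives a true number, 20500 nM. Compound 3 `COc1cc(OC)c2c(=O)cc(C(=O)Nc3ccc(Oc4ccc(F)cc4)cc3)[nH]c2c1` also gives only a limit, > 50000 nM. Compound 3 therefore has no measured number, and only compound 2 offers a firm reference point.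

Compound 4 `COc1cc(OC)c2c(=O)cc(C(=O)Nc3ccc(-n4cccc4)cc3)[nH]c2c1` carries 1H-pyrrol-1-yl in place of 4-fluorophenoxy on an aromatic carbon. Two measured steps change this same group but give no usable size: a step that the limit leaves unreadable from compound 1 to compound 2 and a step that the two limits leave unreadable from compound 1 to compound 3. The only readable one, an at least 2.4-fold higher number from compound 2 to compound 3 (0.38 log units; beyond the scatter), is a modest change, and it leaves the phenoxy link in place. None of the three replaces that link with a directly attached five-membered ring, so the guide is loose. A modest step toward a lower number is expected, with a real chance of another limit.

The expected change is an at least 2.0-fold lower number from compound 3 to compound 4 (0.30 log units; that floor lies within the scatter). Compound 4 is estimated at 25000 nM, with an expected range of 8000 nM to 60000 nM.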

Compound 4, half-maximal effective concentration: > 77000 nM
Compound 4: no number, only a limit; the forecaster's own chance of this, stated with the estimate: 50%; middle value at least 3.0-fold (0.48 log units) away from the limit.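

In this assay compound 4 gives only a limit, so replacing 4-fluorophenoxy with 1H-pyrrol-1-yl on this aromatic carbon still yields no true number: the limit of > 77000 nM in this assay, at which 1 of the 4 values shown sits. For the compounds shown here, the one readable comparison is an at least 3.7-fold higher number from compound 2 to compound 4 (0.57 log units; beyond the scatter), which shows that a directly attached five-membered ring, with no phenoxy link, does not bring the number down to that of compound 2. The steps linking compound 4 to compound 3 and to compound 1 cannot be read, as each joins two limits.

With limits for three of the four compounds, no order among those three can be given, and compound 2 remains the only firm reference point. From the compounds shown here alone, it stays open how a carboxylic acid or a morpholine at this position would read in this assay, and whether any group here gives a number clearly lower than that of compound 2.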